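The compounds below may be only part of what the source reports. "The series", "measured", "known", "first", "only" and "open" are said of these compounds alone.

Measured so far in an assay on isolated protein for inhibition of Indoleamine 2,3-dioxygenase 1 (Homo sapiens), with a stated time of 60 min, tested at 10 uM; on this read-out lower numbers stand for less inhibition and higher numbers for more inhibition at the one concentration tested (going by the name of the read-out):

compound 1, `c1ccc(CCc2ccccc2CSC2=NCCS2)cc1`, gives 0%
compound 2, `Clc1ccc2[nH]c(SCc3ccccc3/C=C\c3ccccc3)nc2c1`, gives 49%
compound 3, `c1ccc(CCc2ccccc2CSc2nccs2)cc1`, gives 31%

Compound 2 stands highest of the three numbers. Compound 3 is the nearest to it and compound 1 the furthest, and both gaps lie beyond the scatter. Among the compounds with values here, the only step between compounds that differ in one place is a number 31 percentage points higher from compound 1 to compound 3 (beyond the scatter), a change on the sulfur that leaves the rest of the molecule as it was.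

Compound 4, `Clc1ccc2[nH]c(SCc3ccccc3Cc3ccccc3)nc2c1`, differs from compound 2 by benzyl in place of 2-phenylethenyl on an aromatic carbon. Within the data shown here, no measured step touches this part of the structure, so nothing measured bears directly on it; the one measured step concerns a different position. With the core of compound 2 retained, a small step in this assay or none beyond the scatter is expected: a number 7 percentage points lower from compound 2 to compound 4 (within the scatter). Compound 4 is therefore estimated at 42%, with a range from 22% to 62%.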

Compound 4, a percentage reported as inhibition, at one concentration (the size of the read-out at that concentration, not a potency): 46%
For compound 4 the middle estimate is 4 percentage points below the measured one, within the range that was stated.
By their numbers in this assay, from the lowest: compound 1; then compound 3; then compounds 4 and 2 (each within the scatter of the next).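

In this assay, replacing 2-phenylethenyl with benzyl on an aromatic carbon, ortho to a large group, gives a number 3 percentage points lower from compound 2 to compound 4 (within the scatter). Within the data shown here, this is the first measured step at this position, and in this one pair neither the double bond outside aromatic rings nor the additional carbon of 2-phenylethenyl separates the two compounds beyond the scatter. No available evidence accounts for this result.

On these data alone, it remains open whether the number in this assay is higher, lower or level with a group at this position without the aromatic ring, such as an amine or a carboxylic acid, or with a longer chain such as 3-phenylpropyl. As far as these compounds go, it also remains open whether the step from 2-phenylethenyl to benzyl reads the same when the sulfur carries the five-membered aromatic ring of compound 3 rather than the shared core of compound 2 and compound 4.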